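Azetidinyl for Cyclobutyloxy on a Long-Chain Pyrimidinol

This account rests on a few compounds, and the source may have more. Where it says the series, first, only, none or still open, it means among the compounds named here.

Measured compounds:
compound 1, `Cc1nc(OC2CCC2)nc(N2CCC2)c1O`, 96%
compound 2, `CCCCCCCCCCCCCCc1nc(OC2CCC2)nc(N2CCC2)c1O`, 54%
compound 3, `Cc1nc(N2CCC2)nc(N2CCC2)c1O`, 85%

In a functional assay on cells (Lymphocyte, Homo sapiens), read by a luciferase reporter and ATP content, with a stated time of 48 h, tested at 20 uM (a higher number here means a weaker effect of the compound at the concentration tested, a lower number a stronger effect), compound 1 gives 96%, while compound 3 gives 85%. The two differ in one place: azetidin-1-yl in place of cyclobutyloxy on an aromatic carbon. That change made a step of a number 11 percentage points lower from compound 1 to compound 3 (beyond the scatter). Compound 2 carries a tetradecyl chain where compound 1 has a methyl, and the difference between the two cores is not broken down here; in this assay compound 2 gives 54%, the lowest of the three numbers.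

Compound 4, `CCCCCCCCCCCCCCc1nc(N2CCC2)nc(N2CCC2)c1O`, is not yet measured. It stands to compound 2 as compound 3 stands to compound 1: azetidin-1-yl in place of cyclobutyloxy on an aromatic carbon. The surroundings differ, since the site in compound 2 is meta to a large group where in compound 1 it is meta to a methyl group, so this is the same kind of change rather than the same change. Resting on the step from compound 1 to compound 3, a step of about a number 10 percentage points lower from compound 2 to compound 4 (within the scatter) is expected from compound 2 to compound 4. Compound 4 is therefore estimated at 44%, expected between 30% and 58%.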

Compound 4, a percentage reported as activity, at one concentration (the size of the read-out at that concentration, not a potency): 1%
Compound 4: the middle estimate sits 43 percentage points above what was measured; the whole stated range lies above it.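

In this assay, putting azetidin-1-yl in place of cyclobutyloxy on the tetradecyl-bearing core gave a number 53 percentage points lower from compound 2 to compound 4 (beyond the scatter), leaving compound 4 at 1%. The direction of the change carried from one core to the other, but its size did not: the same change on two cores in this assay, a number 11 percentage points lower (beyond the scatter) from compound 1 to compound 3 and a number 53 percentage points lower (beyond the scatter) from compound 2 to compound 4, 42 percentage points apart, beyond the scatter of two such steps A step read on the methyl-bearing core was therefore a poor guide to the size of the same kind of change on the tetradecyl-bearing core, although two pairs give no general rule and do not show what sets the size of the step.

The compounds shown leave open how the step behaves with a chain of intermediate length, such as octyl, and whether its size follows chain length at all. They also leave open whether an open-chain amine such as dimethylamino, in place of cyclobutyloxy, would go with a similar step on the tetradecyl-bearing core.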